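This account rests on a few compounds, and the source may have more. Where it says the series, first, only, none or still open, it means among the compounds named here.

Going by the values given here, compound 2 `Fc1ccc(C2(c3ccc(F)cc3)CNC(c3cncnc3)=N2)cc1` stands at the weaker end of the two numbers measured so far in an assay on LM cells for displacement of a labelled ligand from Neuropeptide Y receptor type 5 (Homo sapiens) (on this read-out higher numbers stand for weaker inhibition and lower numbers for stronger inhibition), where compound 2 gives 47 nM. Among the compounds with values here, its nearest neighbour is compound 1 `Fc1ccc(C2(c3ccc(F)cc3)CNC(c3cccc(F)c3)=N2)cc1`, which in this assay gives 10 nM, so that the change a 4.7-fold higher number from compound 1 to compound 2 (0.67 log units; beyond the scatter) marks the only step measured to date. Compound 3 `N#Cc1cccc(C2=NC(c3ccc(F)cc3)(c3ccc(F)cc3)CN2)n1` differs from compound 2 by 6-cyanopyridin-2-yl in place of pyrimidin-5-yl on a carbon with a double bond to nitrogen. Within the data shown here, the single measured step bears on this change only indirectly: it shows that swapping the aryl group on that carbon shifts the number modestly when pyrimidin-5-yl replaces 3-fluorophenyl, but no measured pair covers a 6-cyanopyridin-2-yl group. Given that compound 1, which carries a ring with no ring nitrogen at that position, gives 10 nM, and that the entering group has one ring heteroatom rather than two, compound 3 is expected to land between the two measured numbers, an expected change of a 1.9-fold lower number from compound 2 to compound 3 (0.27 log units; within the scatter). Compound 3 is therefore estimated in this assay at 25 nM, within a range from 6 nM to 100 nM.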

Compound 3, half-maximal inhibitory concentration: 39 nM
Compound 3: the middle estimate sits 1.6-fold (0.19 log units) below what was measured; measured number inside the range.
By their numbers in this assay, from the lowest: compound 1; then compounds 3 and 2 (each within the scatter of the next).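

In this assay, a 1.2-fold lower number from compound 2 to compound 3 (0.08 log units; within the scatter) lies within the scatter, so on this carbon with a double bond to nitrogen, 6-cyanopyridin-2-yl and pyrimidin-5-yl cannot be told apart, even though they differ in ring hetero atoms and only the former carries a nitrile. Against the 3-fluorophenyl group, the new ring gives a 3.9-fold higher number from compound 1 to compound 3 (0.59 log units; beyond the scatter), which, like a 4.7-fold higher number from compound 1 to compound 2 (0.67 log units; beyond the scatter), lies beyond the scatter, so among these three compounds both rings with ring nitrogen give higher numbers than the ring without one, and no compound goes against this. Nothing available here accounts for this grouping or for the match between compound 2 and compound 3.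

What the compounds shown leave open is how much of the step from the 3-fluorophenyl group goes with the ring nitrogen and how much with the nitrile, a question that a plain pyridin-2-yl group would bear on. They also leave open whether a plain phenyl ring, or a pyridine ring carrying an amine or a carboxylic acid in place of the nitrile, would stay in the same range on this carbon.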